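This account rests on a few compounds, and the source may have more. Where it says the series, first, only, none or still open, it means among the compounds named here.

In a functional assay on U-937 cells (Homo sapiens) for antiproliferative activity, read by MTT assay, with a stated time of 72 h (a lower number here means a stronger inhibitor, a higher number a weaker inhibitor), compound 3 (`Nc1ccccc1NC(=O)CCCCCCc1nc(-c2ccccc2)no1`) gives 730 nM and stands second highest of the three measured compounds. Compound 2 (`O=C(CCCCCCc1nc(-c2cccnc2)no1)NO`) lies lower at 350 nM and compound 1 (`O=C(CCCCCCc1nc(-c2ccc(C(F)(F)F)cc2)no1)NO`) lies higher at 2870 nM and both gaps from compound 3 go beyond the usual scatter. Compound 1 and compound 2 each differ from compound 3 in more than one place, so neither comparison isolates a single change.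

Compound 4 (`Nc1ccccc1NC(=O)CCCCCCc1nc(-c2ccccc2Cl)no1`) departs from compound 3 by chloro in place of hydrogen on an aromatic carbon and thus carries chloro in place of hydrogen on an aromatic carbon, turning phenyl to 2-chlorophenyl. Among the measured compounds shown here, no measured pair shows this change on its own, so the size of the step in this assay can only be judged loosely. A step within the scatter is expected, with a slight rise in the number somewhat more likely than a fall. The estimated 1.1-fold higher number from compound 3 to compound 4 (0.04 log units; within the scatter) stays within that scatter. For compound 4 the expected value is 800 nM within an estimated span of 320 nM to 2000 nM at its two ends.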

Compound 4, half-maximal inhibitory concentration: 6910 nM
Compound 4: the middle estimate sits 8.6-fold (0.94 log units) below what was measured; measured number above the stated range.
By their numbers in this assay, from the lowest: compound 2; then compound 3; then compound 1; then compound 4.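

In this assay, turning phenyl to 2-chlorophenyl gives a 9.5-fold higher number from compound 3 to compound 4 (0.98 log units; beyond the scatter), the first single-place step seen in this series. It shows that a lone chloro on an aromatic carbon ortho to a large group is enough to carry the number well beyond the scatter, and that the change weakens rather than leaves the activity unchanged. Nothing available explains the size of this step.

On these data alone, whether the rise belongs to this position or to chloro itself stays open; a fluoro or a methyl on the same carbon, or chloro elsewhere on the ring, would separate the two. Also open, as far as these compounds go, is whether the same change would act alike on the end group that compound 1 and compound 2 carry in place of the aminophenyl amide.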